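From Methoxy to Hydroxy: Compound 2 and Compound 4

The source may report more compounds than this note shows. Statements on the series, on what has been measured and on what is new or still open speak of the compounds shown alone.

In a functional assay on HT-29 cells (Homo sapiens) for cytotoxicity, read by XTT assay, with a stated time of 72 h (a higher number here means a weaker inhibitor, a lower number a stronger inhibitor), compound 2 `C=C1CC[C@H]2C(C)(C)CCC[C@]2(C)[C@H]1CC/C(C)=C/COc1cc(O)c2c(=O)c(O)c(-c3ccc(OC)cc3)oc2c1` gives > 100000 nM, which is a limit of the assay and not a number. Its place among the results is the limit of > 100000 nM in this assay, at which 1 of the 3 values shown sits.

The other two results are numbers. Compound 1 `CC(C)=CCC/C=C(\C)Cc1c(O)cc(O)c2c(=O)c(OC/C=C(\C)CCC=C(C)C)c(-c3ccc(O)cc3)oc12` gives 30000 nM, and compound 3 `CC(C)=CCC/C(C)=C/COc1c(-c2ccc(O)cc2)oc2cc(O)cc(O)c2c1=O` gives 25000 nM. Going by the values given here, the one measured step between them is a 1.2-fold lower number from compound 1 to compound 3 (0.08 log units; within the scatter); there, hydrogen takes the place of 2,7-dimethylocta-2,6-dien-1-yl on an aromatic carbon.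

Compound 4 `C=C1CC[C@H]2C(C)(C)CCC[C@]2(C)[C@H]1CC/C(C)=C/COc1cc(O)c2c(=O)c(O)c(-c3ccc(O)cc3)oc2c1` differs from compound 2 by a single change, hydrogen in place of methyl on an oxygen on an aromatic ring, turning 4-methoxyphenyl into 4-hydroxyphenyl. Among the compounds with values here, no measured step makes this change, so the step between compound 1 and compound 3 sets no direct size for it.

Within the data shown here, the only guide is loose, since compound 3 also carries 4-hydroxyphenyl and gives 25000 nM, though it differs from compound 4 elsewhere too. A modest move towards a lower number, meaning a stronger inhibitor, is therefore expected, and the result could still be only a limit. The expected size is an at least 2.0-fold lower number from compound 2 to compound 4 (0.30 log units; that floor lies within the scatter). For compound 4, the estimated value is 50000 nM, with an expected range of 15000 nM to 100000 nM.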

Compound 4, half-maximal inhibitory concentration: > 100000 nM
Compound 4 gave a limit, no number; the forecaster's own chance of this, stated with the estimate: 35%; at least 2.0-fold (0.30 log units) between middle value and limit.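

In this assay compound 4 gives > 100000 nM, a limit of the assay and not a number. Compound 2 also stands at a limit, so no step can be read between compound 2 and compound 4: the limit of > 100000 nM in this assay, at which 2 of the 4 values shown sit.

The compounds shown leave open how far, if at all, changing 4-methoxyphenyl to 4-hydroxyphenyl moves the result in this assay.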